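The source may hold more compounds than are shown below. What is called first, only, known or untested is meant among the compounds shown, and "the series" means these compounds.

Measured so far:
Compound 1, `Cc1ccccc1OCC(=O)Nc1ccc(OCC(=O)O)c(F)c1` — "not determined" (no result reported).
Compound 2, `CCc1ccc(OCC(=O)Nc2ccc(OCC(=O)O)c(F)c2)cc1` — "not determined" (no result reported).
Compound 3, `CC(C)(C)c1cccc(OCC(=O)Nc2ccc(OCC(=O)O)c(F)c2)c1` — 122 nM.

All three compounds share the same core, a fluorinated phenoxyacetic acid linked through an amide to a second aromatic ring, and differ only in the group on that second ring. Going by the values given here, in a functional assay on CHO cells for agonist activity at Free fatty acid receptor 1 (Homo sapiens), read by FLIPR (a higher number here means that more compound is needed for the effect, a lower number that less compound is needed), compound 3 gives 122 nM, and this is the only number available: for compound 1 and compound 2 no result was reported in this assay, so compound 3 stands alone without any comparison.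

Compound 4, `COc1cccc(OCC(=O)Nc2ccc(OCC(=O)O)c(F)c2)c1`, has not yet been measured. Its change from compound 3 is methoxy in place of tert-butyl on an aromatic carbon. Among the compounds with values here, no pair of measured compounds shows what such a change does here, so any step can only be an expectation. The expectation is that the step from compound 3 to compound 4, a 4.1-fold higher number from compound 3 to compound 4 (0.61 log units; beyond the scatter), goes towards more compound needed, and clearly beyond the usual scatter. Compound 4 is therefore estimated at 500 nM in this assay, with a range from 150 nM to 2000 nM.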

Compound 4, half-maximal effective concentration: 148 nM
The estimate for compound 4 lay 3.4-fold (0.53 log units) above the measured number; measured number below the stated range.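

In this assay, putting methoxy in place of tert-butyl on this aromatic carbon gives a 1.2-fold higher number from compound 3 to compound 4 (0.08 log units; within the scatter), so the two compounds cannot be told apart. This first comparison at the position shows that two quite different groups, one made only of carbon and the smaller one carrying an oxygen, can sit here without a change in the number that exceeds the usual scatter. No measurement shown here explains why the swap makes so little difference.

On these data alone, whether the same holds for other groups at this position, such as an amine, a carboxylic acid or a longer chain, remains open. With no number for compound 1 or compound 2, it is also unknown how groups placed elsewhere on this ring would behave.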